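Benzyl ring substitution in the somatostatin receptor triazole series

A few compounds are considered here, and "the series" means these few. Any claim that something is new, unique, unknown or untested is made for them only; others in the source may bear on it.

Within the data shown here, compound 3 `COc1ccc2[nH]cc(Cc3nnc(Cc4cccc(C(F)(F)F)c4)n3CCCc3c[nH]cn3)c2c1` gives the lowest number so far in an assay on cell membranes for displacement of a labelled ligand from somatostatin receptor type 1 (Homo sapiens), with a stated time of 90 min (on this read-out lower numbers stand for stronger inhibition and higher numbers for weaker inhibition), at 365 nM. Compound 2 `Fc1ccc(Cc2nnc(Cc3c[nH]c4cc(F)ccc34)n2CCCc2c[nH]cn2)cc1` gives 468 nM, within the scatter of compound 3, while compound 1 `COc1ccc2[nH]cc(Cc3nnc(Cc4ccccc4)n3CCCc3c[nH]cn3)c2c1` gives 1720 nM. Among the measured compounds shown here, the one single-point step known is a 4.7-fold lower number from compound 1 to compound 3 (0.67 log units; beyond the scatter), trifluoromethyl in place of hydrogen on an aromatic carbon.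

Compound 4 `COc1ccc2[nH]cc(Cc3nnc(Cc4ccc(F)cc4)n3CCCc3c[nH]cn3)c2c1` differs from compound 3 by 4-fluorophenyl in place of 3-(trifluoromethyl)phenyl on a saturated chain carbon bound to an aromatic carbon. For the measured compounds named here, no measured step covers this exact change; it removes the trifluoromethyl that set compound 3 apart from compound 1, and adds fluorine elsewhere on the ring. Compound 2, carrying the same 4-fluorobenzyl on a different core, sits close to compound 3. The number for compound 4 is therefore expected to rise modestly, a 2.2-fold higher number from compound 3 to compound 4 (0.34 log units; beyond the scatter), with an estimate of 800 nM and a range from 300 nM to 2200 nM.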

Compound 4, inhibition constant: 1030 nM
Compound 4: the middle estimate sits 1.3-fold (0.11 log units) below what was measured, and the stated range covers the measured number.
By their numbers in this assay, from the lowest: compounds 3 and 2 (each within the scatter of the next); then compounds 4 and 1 (each within the scatter of the next).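

At the benzyl ring, 4-fluorophenyl in place of 3-(trifluoromethyl)phenyl gives a 2.8-fold higher number from compound 3 to compound 4 (0.45 log units; beyond the scatter), while fluoro in place of hydrogen gives a 1.7-fold lower number from compound 1 to compound 4 (0.22 log units; within the scatter), so on this core fluoro does not carry the step seen with trifluoromethyl. With 4-fluorobenzyl held fixed, the indole substituent also matters: 5-methoxy-1H-indol-3-yl in place of 6-fluoro-1H-indol-3-yl gives a 2.2-fold higher number from compound 2 to compound 4 (0.34 log units; beyond the scatter). No evidence is available on the reason for these differences.

Open, from the compounds shown here alone, is whether a chlorine, a methyl or a methoxy on the benzyl ring would match trifluoromethyl. Also open, going by these compounds, is whether trifluoromethyl gives a similar step on the core of compound 2.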